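This account rests on a few compounds, and the source may have more. Where it says the series, first, only, none or still open, it means among the compounds named here.

In an ADME assay on HeLa cells (Homo sapiens) for inhibition, read by MTT assay (on this read-out lower numbers stand for stronger inhibition of growth and higher numbers for weaker inhibition of growth), three compounds sharing one core have been measured. Compound 1 `Cc1nc(C)c(-c2nn(-c3ccc(F)cc3)cc2/C=C/C(=O)c2cc(Br)ccc2O)s1` gives 4.88 ug/mL, and compound 2 `Cc1ccc(O)c(C(=O)/C=C/c2cn(-c3ccc(F)cc3)nc2-c2sc(C)nc2C)c1` gives 29.9 ug/mL. Compound 3 `Cc1nc(C)c(-c2nn(-c3ccc(F)cc3)cc2/C=C/C(=O)c2cc(Cl)cc(Cl)c2O)s1` gives > 250 ug/mL, which is a limit of the assay and not a number. Compound 3 therefore stands at the weak end of the three, without an exact place.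

Compound 4 `Cc1nc(C)c(-c2nn(-c3ccc(F)cc3)cc2/C=C/C(=O)c2c(O)cc(C)c(Cl)c2C)s1` carries a different group on the carbonyl carbon: 3-chloro-6-hydroxy-2,4-dimethylphenyl in place of 3,5-dichloro-2-hydroxyphenyl on a carbonyl carbon.

Three measured steps change the ring at this same place, and all lie beyond the scatter: a 6.1-fold higher number from compound 1 to compound 2 (0.79 log units; beyond the scatter), a modest one; an at least 51-fold higher number from compound 1 to compound 3 (1.70 log units; beyond the scatter), a large one; and an at least 8.3-fold higher number from compound 2 to compound 3 (0.92 log units; beyond the scatter), at least modest. So changes here have moved the number considerably. As far as these compounds go, the ring of compound 2 carries a methyl and gives 29.9 ug/mL, which points towards lower numbers, although the ring of compound 4 is untested. In this assay, a clear step towards lower numbers is expected, estimated as an at least 4.1-fold lower number from compound 3 to compound 4 (0.61 log units; beyond the scatter). For compound 4, the estimate is 60 ug/mL, with an expected range of 12 ug/mL to 250 ug/mL.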

Compound 4, concentration for 50% growth inhibition: 59.3 ug/mL
Compound 4: the middle estimate sits 1.0-fold (0.01 log units) above what was measured; the range from low to high includes it.
By their numbers in this assay, from the lowest: compound 1; then compounds 2 and 4 (each within the scatter of the next). At a limit, above all of these: compound 3.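

Chlorine on the ring at this carbonyl carbon does not by itself push the number to the weak end, since the 3-chloro-6-hydroxy-2,4-dimethylphenyl group, with one chlorine and two methyl groups, gives an at least 4.2-fold lower number from compound 3 to compound 4 (0.62 log units; beyond the scatter). This more crowded ring cannot be told apart from the 2-hydroxy-5-methylphenyl group, with a 2.0-fold higher number from compound 2 to compound 4 (0.30 log units; within the scatter), whereas the 5-bromo-2-hydroxyphenyl group keeps a clear lead, with a 12-fold higher number from compound 1 to compound 4 (1.08 log units; beyond the scatter). Compound 3 remains a limit and not a number, so its steps have only one bound: the limit of > 250 ug/mL in this assay, at which 1 of the 4 values shown sits.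

As far as these compounds go, the new ring differs from the old one in several substituents at once, so the share of each methyl group and of the lost chlorine stays unknown. Also open, from the compounds shown here alone, is how this position would respond to a different kind of group on the ring, such as an amine or a methoxy group.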